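Swapping selenium for sulfur on a fused two-ring core

This account rests on a few compounds, and the source may have more. Where it says the series, first, only, none or still open, it means among the compounds named here.

Compound 1 `Sc1nc(NCc2ccccc2)c2ccccc2n1` and compound 2 `C[Se]c1nc(NCc2ccccc2)c2ccccc2n1` share a fused two-ring core carrying a benzylamino group. In a functional assay on MCF7 cells (Homo sapiens) for cytotoxicity, read by MTT assay, with a stated time of 72 h (on this read-out higher numbers stand for weaker inhibition of growth and lower numbers for stronger inhibition of growth), compound 1 gives 27200 nM, while compound 2 gives 15800 nM; the two numbers sit within the scatter of each other, as the step of a 1.7-fold lower number from compound 1 to compound 2 (0.24 log units; within the scatter) shows, so neither compound can be called more potent on this assay. Compound 3 `CSc1nc(NCc2ccccc2)c2ccccc2n1` differs from compound 2 only in one place: a group of 2 heavy atoms (1 carbon, 1 sulfur; no ring) in place of a group of 2 heavy atoms (1 carbon, 1 selenium; no ring), on an aromatic carbon. Within the data shown here, the single measured step concerns the same position and was small, which suggests that exchanging selenium for sulfur here changes little. Compound 3 is therefore expected to land close to compound 2, with the step of a 1.3-fold higher number from compound 2 to compound 3 (0.10 log units; within the scatter) not expected to exceed the scatter. The estimate for compound 3 in this assay is 20000 nM, in a range from 7000 nM to 60000 nM.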

Compound 3, concentration for 50% growth inhibition: 41500 nM
Compound 3: middle estimate off by 2.1-fold (0.32 log units), on the low side; low and high end bracket the measured number.
By their numbers in this assay, from the lowest: compounds 2, 1 and 3 (each within the scatter of the next, the first and the last beyond it).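

With the methyl kept in place, the atom linking it to the core can now be judged alone: in this assay, putting sulfur in place of selenium at this carbon between two ring nitrogen atoms gives a 2.6-fold higher number from compound 2 to compound 3 (0.42 log units; beyond the scatter), a modest step that leaves the selenium compound as the stronger growth inhibitor of this pair. Adding a methyl on the sulfur, by contrast, gives a 1.5-fold higher number from compound 1 to compound 3 (0.18 log units; within the scatter), so that change has no effect that can be told apart from ordinary repeat variation. No measurement offered here explains the gap between selenium and sulfur.

Still open, going by these compounds, is how a longer chain on the sulfur or selenium, such as an ethyl or a butyl, would behave at this carbon. An amine at the same carbon would also test whether the linking atom matters beyond these compounds.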